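The source may report more compounds than this note shows. Statements on the series, on what has been measured and on what is new or still open speak of the compounds shown alone.

In an assay on isolated protein for inhibition of DNA topoisomerase 1 (Homo sapiens), with a stated time of 15 min (on this read-out lower numbers stand for stronger inhibition and higher numbers for weaker inhibition), compound 3 `COc1c(N2CC[C@@H](CN)C2)c(F)cc2c(=O)c(C(=O)O)cn(Cc3cc(-c4ccccc4)no3)c12` gives 178000 nM, the highest of the two numbers recorded here. Its nearest neighbour, compound 1 `COc1c(N2CC[C@@H](CN)C2)c(F)cc2c(=O)c(C(=O)O)cn(Cc3ccc(-c4ccccc4)cc3)c12`, gives 26000 nM in this assay, and the step of a 6.8-fold higher number from compound 1 to compound 3 (0.84 log units; beyond the scatter) exchanges one aryl group for another on the saturated chain carbon bound to the aromatic nitrogen. Compound 2 `NC[C@@H]1CCN(c2cc3c(cc2F)c(=O)c(C(=O)O)cn3Cc2nc(-c3ccncc3)no2)C1` reaches only the limit of this assay, > 200000 nM, so no number is known for it. Compound 4 `NC[C@@H]1CCN(c2cc3c(cc2F)c(=O)c(C(=O)O)cn3Cc2cc(-c3ccccc3)no2)C1` differs from compound 3 by hydrogen in place of methoxy on an aromatic carbon. Within the data shown here, no measured step isolates this change: compound 1 and compound 2 differ both in the methoxy and in the aryl group, so their values show no more than that one of them sits at the limit (the limit of > 200000 nM in this assay, at which 1 of the 3 values shown sits). Without a direct precedent, the step is expected to stay small or run toward weaker inhibition, giving a 1.2-fold higher number from compound 3 to compound 4 (0.09 log units; within the scatter). Compound 4 is therefore estimated at 220000 nM, within a range from 90000 nM to 600000 nM, with a real chance that this assay reports only a limit.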

Compound 4, half-maximal inhibitory concentration: 58300 nM
Compound 4: the middle estimate sits 3.8-fold (0.58 log units) above what was measured; measured number outside the range, below it.
By their numbers in this assay, from the lowest: compound 1; then compound 4; then compound 3. At a limit, above all of these: compound 2.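

Among these compounds, this is the first direct reading of the change: in this assay, replacing methoxy with hydrogen on the carbon ortho to the 3-(aminomethyl)pyrrolidin-1-yl group gives a 3.1-fold lower number from compound 3 to compound 4 (0.48 log units; beyond the scatter), so methoxy is not needed here for inhibition when the 3-phenyl-1,2-oxazol-5-yl group is present. With hydrogen on that carbon, the group on the saturated chain carbon also counts, as exchanging the 3-(pyridin-4-yl)-1,2,4-oxadiazol-5-yl group gives an at least 3.4-fold lower number from compound 2 to compound 4 (0.53 log units; beyond the scatter). Compound 2 has a limit rather than a number, so the true size of that step stays unknown: the limit of > 200000 nM in this assay, at which 1 of the 4 values shown sits.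

As far as these compounds go, whether hydrogen would also give stronger inhibition than methoxy alongside the 4-phenylphenyl group of compound 1 remains open. So does how an ethoxy group, a hydroxyl or an amine on this carbon would compare with hydrogen.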